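This account rests on a few compounds, and the source may have more. Where it says the series, first, only, none or still open, it means among the compounds named here.

Three compounds share one core and differ only in the chain carried on the aromatic nitrogen, and all three have been measured in a functional assay (trachea) with Cavia porcellus as the target; on this read-out lower numbers stand for stronger inhibition and higher numbers for weaker inhibition. Compound 1 `CCCn1nc(-c2cccnc2)c2ccccc2c1=O` gives 3160 nM, compound 2 `C=CCn1nc(-c2cccnc2)c2ccccc2c1=O` gives 2140 nM, and compound 3 `COCCn1nc(-c2cccnc2)c2ccccc2c1=O` gives 9330 nM. Compound 3 stands at the top of these three numbers and is thus the weakest inhibitor of the set: there is a 3.0-fold higher number from compound 1 to compound 3 (0.47 log units; beyond the scatter) and a 4.4-fold higher number from compound 2 to compound 3 (0.64 log units; beyond the scatter), whereas a 1.5-fold lower number from compound 1 to compound 2 (0.17 log units; within the scatter).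

Compound 4 `O=c1c2ccccc2c(-c2cccnc2)nn1CCO` has not yet been measured. It differs from compound 3 by hydrogen in place of methyl on an oxygen on a saturated carbon, so the chain now ends in a hydroxy group rather than a methoxy group. Among the measured compounds shown here, no measured step touches this oxygen. The nearest step on record is a 3.0-fold higher number from compound 1 to compound 3 (0.47 log units; beyond the scatter), where a methoxy entered in place of a methyl and the number rose, but that says nothing about taking the methyl off the oxygen while the oxygen stays. For the measured compounds named here, with no step bearing directly on the change, the expectation for compound 4 is a 1.0-fold lower number from compound 3 to compound 4 (0.02 log units; within the scatter), a step taken to lie within the scatter. Compound 4 is therefore estimated to give 9000 nM in this assay, with a range from 3000 nM to 27000 nM.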

Compound 4, half-maximal inhibitory concentration: 4570 nM
For compound 4 the middle estimate is 2.0-fold (0.29 log units) above the measured one, within the range that was stated.
By their numbers in this assay, from the lowest: compounds 2, 1 and 4 (each within the scatter of the next, the first and the last beyond it); then compound 3.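

Among the compounds shown here, replacing the methyl on the oxygen with hydrogen, which turns the 2-methoxyethyl chain into 2-hydroxyethyl, is the first change here made at that oxygen, and in this assay it gives a 2.0-fold lower number from compound 3 to compound 4 (0.31 log units; beyond the scatter) and so shows that the end of the chain still counts while the oxygen itself stays. The chain with hydroxy in place of the terminal methyl gives a 1.4-fold higher number from compound 1 to compound 4 (0.16 log units; within the scatter) and therefore cannot be told apart from the propyl chain of compound 1, whereas the vinyl-bearing chain of compound 2 remains distinct, with a 2.1-fold higher number from compound 2 to compound 4 (0.33 log units; beyond the scatter) as the step. An oxygen on this chain therefore does not by itself bring the higher number seen for compound 3, although nothing on hand explains why the methyl on that oxygen makes this difference.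

Still open, on these data alone, is how other groups at the end of this chain would behave, such as an amine, a carboxylic acid, or a longer chain ending in hydroxy. As far as these compounds go, all four compounds also share one core, so whether methoxy to hydroxy would give a similar step on a different core remains unknown.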